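The compounds below may be only part of what the source reports. "The series", "measured", "known", "first", "only" and "open" are said of these compounds alone.

Compound 2 `O=C(NC(=S)NNc1ncnc2ccccc12)c1ccc(F)cc1` stands at the lowest of the three numbers recorded in a functional assay on MCF7 cells (Homo sapiens) for cytotoxicity, read by MTT assay, with a stated time of 72 h (a lower number here means a stronger inhibitor, a higher number a weaker inhibitor), where compound 2 gives 4590 nM. Compound 1 `COc1cc2ncnc(NNC(=S)NC(=O)c3ccccc3F)c2cc1OC` comes nearest, with compound 1 giving 8500 nM, a gap that stays within the usual scatter. Compound 3 `COc1cc2ncnc(NNC(=S)NC(=O)c3ccc(C(F)(F)F)cc3)c2cc1OC` lies furthest away, with compound 3 giving 16800 nM, a gap that exceeds the scatter.

Compound 4 `O=C(NC(=S)NNc1ncnc2ccccc12)c1cccc(Cl)c1` has not yet been measured in this assay. Its structure departs from compound 2 in a single place: 3-chlorophenyl in place of 4-fluorophenyl on a carbonyl carbon. The shared core and the linker between the core and the carbonyl are kept unchanged.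

For the measured compounds named here, the one measured step that touches the same position is the exchange of the aryl group on the carbonyl carbon between compound 1 and compound 3, which gave a 2.0-fold higher number from compound 1 to compound 3 (0.30 log units; within the scatter). That step sat on a core carrying two methoxy groups, whereas compound 2 and compound 4 share an unsubstituted core, so the comparison is only indirect. Taken on its own it suggests that swapping one substituted phenyl for another at this position shifts the number little. The expected step from compound 2 to compound 4 is therefore a 1.2-fold higher number from compound 2 to compound 4 (0.08 log units; within the scatter), judged to lie within the scatter. Compound 4 is estimated at 5500 nM, with a range from 2000 nM to 15000 nM.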

Compound 4, half-maximal inhibitory concentration: 3540 nM
Estimate against measurement, compound 4: 1.6-fold (0.19 log units) above, within the range that was stated.
By their numbers in this assay, from the lowest: compounds 4, 2, 1 and 3 (each within the scatter of the next, the first and the last beyond it).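

For the compounds shown here, this is the first step at the aryl group on a carbonyl carbon read on the unsubstituted shared core: in this assay the exchange of 4-fluorophenyl for 3-chlorophenyl gives a 1.3-fold lower number from compound 2 to compound 4 (0.11 log units; within the scatter) and so leaves the number in place. Together with a 2.0-fold higher number from compound 1 to compound 3 (0.30 log units; within the scatter) on the core carrying two methoxy groups, there are now two exchanges of one substituted phenyl for another at this position, on two different cores, and neither step goes beyond the scatter, so across these four compounds the number tolerates these changes of the aryl group. No measurement at hand explains why these exchanges leave the number so little changed.

The change from compound 2 to compound 4 alters the halogen and its place on the ring together, so the two cannot be told apart, and no pair shown differs only in the two methoxy groups on the core. From the compounds shown here alone, it also remains open whether the number would hold with an amine or a carboxylic acid on the phenyl ring, or with a longer chain in place of the phenyl on the carbonyl carbon.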